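Swapping the aryl group on the ring nitrogen of compound 3

The source may report more compounds than this note shows. Statements on the series, on what has been measured and on what is new or still open speak of the compounds shown alone.

Compounds measured in a functional assay on A549 cells (Homo sapiens) for inhibition, read by MTT assay, with a stated time of 72 h; a lower number here means a stronger inhibitor, a higher number a weaker inhibitor:
Compound 1 `COc1cc2c(Oc3ccc(NC(=O)c4nn(-c5ccccc5)cc(C)c4=O)cc3F)ccnc2cc1OCCCCCC(=O)NO`, compound 1 gives 4170 nM
Compound 2 `COc1cc2c(Oc3ccc(NC(=O)c4nn(-c5ccccc5C)cc(C)c4=O)cc3)ccnc2cc1OCCCCCC(=O)NO`, compound 2 gives 1820 nM
Compound 3 `COc1cc2c(Oc3ccc(NC(=O)c4nn(-c5ccccc5C)cc(C)c4=O)cc3)ccnc2cc1OCC(=O)NO`, compound 3 gives 5980 nM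

Compound 3 has the highest number of the three in this assay. Its nearest neighbour is compound 1, whose value lies within the scatter of that of compound 3, so no order between those two can be drawn. Among the measured compounds shown here, compound 2 stands furthest away: the one measured step that reaches compound 3 is a 3.3-fold higher number from compound 2 to compound 3 (0.52 log units; beyond the scatter), which shortens the chain carrying the hydroxycarbamoyl group.

Compound 4 `COc1cc2c(Oc3ccc(NC(=O)c4nn(-c5ccc(Cl)c(C(F)(F)F)c5)cc(C)c4=O)cc3)ccnc2cc1OCC(=O)NO` keeps the short chain of compound 3 and changes only the group on the aromatic nitrogen: 4-chloro-3-(trifluoromethyl)phenyl in place of 2-methylphenyl on an aromatic nitrogen. For the measured compounds named here, no measured pair isolates this kind of change. Compound 1 and compound 2 differ at the same aryl group, but they also differ elsewhere. Compound 1 gives 4170 nM. Compound 2 gives 1820 nM. These two values show only that aryl variation together with other changes moved the number by a modest amount. Going by the values given here, with no step that bears directly on the change, compound 4 is expected to sit close to compound 3, the step being estimated as a 1.2-fold lower number from compound 3 to compound 4 (0.08 log units; within the scatter). Compound 4 is therefore estimated at 5000 nM, with a range from 1500 nM to 16000 nM.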

Compound 4, half-maximal inhibitory concentration: 1590 nM
For compound 4 the middle estimate is 3.1-fold (0.50 log units) above the measured one; low and high end bracket the measured number.
By their numbers in this assay, from the lowest: compounds 4 and 2 (each within the scatter of the next); then compounds 1 and 3 (each within the scatter of the next).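

In this assay, the aryl group on the aromatic nitrogen now has a step of its own: a 3.8-fold lower number from compound 3 to compound 4 (0.58 log units; beyond the scatter), with the short chain of compound 3 held fixed. Among the compounds shown here, until now, aryl variation had appeared only between compound 1 and compound 2, which also differ elsewhere, so this is the first evidence that 4-chloro-3-(trifluoromethyl)phenyl in place of 2-methylphenyl moves the number beyond the scatter without any other change. For the compounds shown here, the only other measured step, a 3.3-fold higher number from compound 2 to compound 3 (0.52 log units; beyond the scatter), concerns the chain, and the two steps are both modest, so the aryl group and the chain each affect the number in this small set, although no measurement given here explains why the aryl change lowered it.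

The compounds shown leave open whether the chlorine or the trifluoromethyl group accounts for the step, since neither 4-chlorophenyl nor 3-(trifluoromethyl)phenyl stands alone on this nitrogen here. They also leave open whether 4-chloro-3-(trifluoromethyl)phenyl would lower the number to a similar extent on compound 2, with its 4-(hydroxycarbamoyl)butyl chain, or whether a pyridyl ring would be tolerated at this position.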